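Compound 3 to compound 4: replacing the 2-nitrophenyl group

The source may report more compounds than this note shows. Statements on the series, on what has been measured and on what is new or still open speak of the compounds shown alone.

Measured so far in a functional assay on BGC-823 cells (Homo sapiens) for cytotoxicity, read by MTT assay, with a stated time of 48 h (on this read-out higher numbers stand for weaker inhibition and lower numbers for stronger inhibition), are three compounds
- compound 1 `O=C(CSc1nnc(-c2ccncc2)o1)N/N=C/c1ccc(Cl)cc1` gives 20500 nM
- compound 2 `O=C(CSc1nnc(-c2ccncc2)o1)N/N=C/c1ccc(O)cc1` gives 7940 nM
- compound 3 `O=C(CSc1nnc(-c2ccncc2)o1)N/N=C/c1ccccc1[N+](=O)[O-]` gives 41600 nM

Compound 3 has the highest number of the three, so it is the weakest inhibitor here. Its nearest neighbour on the scale is compound 1, in a 2.0-fold higher number from compound 1 to compound 3 (0.31 log units; beyond the scatter), and its furthest is compound 2, in a 5.2-fold higher number from compound 2 to compound 3 (0.72 log units; beyond the scatter). Both steps lie beyond the scatter.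

The next change leads to compound 4 `O=C(CSc1nnc(-c2ccncc2)o1)N/N=C/c1ccc(Cl)cc1Cl`, and it is 2,4-dichlorophenyl in place of 2-nitrophenyl on a carbon with a double bond to nitrogen. The step that bears most closely on it is a 2.0-fold higher number from compound 1 to compound 3 (0.31 log units; beyond the scatter), which joins 4-chlorophenyl and the same 2-nitrophenyl. It suggests that leaving 2-nitrophenyl for a chlorinated ring may lower the number modestly. Within the data shown here, no measured step shows what a second chloro does, and a 2.6-fold lower number from compound 1 to compound 2 (0.41 log units; beyond the scatter) shows only that this aryl group can matter. In this assay a modest move towards a lower number is therefore expected, given as a 2.1-fold lower number from compound 3 to compound 4 (0.32 log units; beyond the scatter).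

For compound 4 the estimate is 20000 nM, with an expected range from 8000 nM to 50000 nM.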

Compound 4, half-maximal inhibitory concentration: 35600 nM
Estimate against measurement, compound 4: 1.8-fold (0.25 log units) below; the range from low to high includes it.
By their numbers in this assay, from the lowest: compound 2; then compounds 1, 4 and 3 (each within the scatter of the next, the first and the last beyond it).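

In this assay, the 2,4-dichlorophenyl group of compound 4 cannot be told apart from the 2-nitrophenyl group it replaces (a 1.2-fold lower number from compound 3 to compound 4 (0.07 log units; within the scatter)), so this exchange on the carbon with a double bond to nitrogen leaves the read-out unresolved. The second chloro, chloro in place of hydrogen on an aromatic carbon, is also unresolved (a 1.7-fold higher number from compound 1 to compound 4 (0.24 log units; within the scatter)), which places compound 4 within the scatter of both compound 1 and compound 3, although those two lie just beyond the scatter of each other, and the one clear separation is from the 4-hydroxyphenyl group (a 4.5-fold higher number from compound 2 to compound 4 (0.65 log units; beyond the scatter)). No independent measurement is available to explain these differences.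

The compounds shown leave open whether the lower number of compound 2 is specific to the hydroxy group or would also be seen with a methoxy, an amine or a carboxylic acid on the same ring. They also leave open whether a ring carrying a hydroxy group together with a chloro would stay with compound 2 or join compound 1.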